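Dropping One Chlorine from a Sulfonamide Series

The compounds below may be only part of what the source reports. "The series", "measured", "known", "first", "only" and "open" are said of these compounds alone.

Three compounds sharing a core have been run through an ADME assay on microsomes from liver (Homo sapiens), read by LC-MS, using NADPH, tested at 10 uM; on this read-out lower numbers stand for lower hepatic extraction and higher numbers for higher hepatic extraction. Compound 1 `Cc1ccccc1S(=O)(=O)N1CCN(c2ccc(C(=O)NCc3cccs3)nn2)CC1` gives 0.92. Compound 2 `Cc1ccccc1S(=O)(=O)N1CC2(CN(c3ccc(C(=O)NCc4ccc(F)cc4)nn3)C2)C1` gives 0.97. Compound 3 `O=C(NCc1ccccc1)c1ccc(N2CCN(S(=O)(=O)c3cccc(Cl)c3Cl)CC2)nn1` gives 0.73, the lowest of the three; its nearest neighbour, compound 1, stands higher by a gap beyond the usual scatter, and compound 2 stands further above, also beyond the scatter. Compound 4 `O=C(NCc1ccccc1)c1ccc(N2CCN(S(=O)(=O)c3ccccc3Cl)CC2)nn1` has not yet been tested. It differs from compound 3 in a single place: hydrogen in place of chloro on an aromatic carbon. A chloro group leaves and a hydrogen atom enters on an aromatic carbon of a six-membered aromatic ring of carbon only, so the 2,3-dichlorophenyl of compound 3 becomes a 2-chlorophenyl. Within the data shown here, no pair of measured compounds here shows what such a change does, so the expectation leans on compound 3 alone. With compound 3 at 0.73 as the only anchor, the expected step is small, a number 0.010 lower from compound 3 to compound 4 (within the scatter), in either direction or none beyond the scatter. Compound 4 is therefore estimated at 0.72, within a range from 0.55 to 0.88.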

Compound 4, hepatic extraction ratio: 0.89
Beside the measured number, compound 4's estimate is 0.17 below it; the measured number lies above the stated range.
By their numbers in this assay, from the lowest: compound 3; then compounds 4, 1 and 2 (each within the scatter of the next).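

In this assay the number moves a number 0.16 higher from compound 3 to compound 4 (beyond the scatter) as a single chloro group gives way to hydrogen on the aromatic ring. The earlier compounds shown here differ from one another in more than one place, so none of their gaps could be tied to one spot; this pair ties a change larger than the usual scatter to one aromatic carbon, with the rest of the molecule unchanged. Nothing measured here accounts for the step.

A methoxy group or a nitrile on that same carbon would show whether the lower number goes with chloro specifically or with any group other than hydrogen. As far as these compounds go, whether the same step would appear on the core of compound 2 also remains open.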